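The source may hold more compounds than are shown below. What is called first, only, known or untested is meant among the compounds shown, and "the series" means these compounds.

Compound 1: `COc1cc(N(CC2CC2)c2ccc(Cl)c(Cl)c2)cnc1C(=O)[C@H]1C[C@@H]1C(=O)O`, in an assay on isolated protein for inhibition of leukotriene C4 synthase (Homo sapiens), read by LC-MS, with stated times of 45 min and 20 min (a higher number here means a weaker inhibitor, a lower number a stronger inhibitor), gives 27.7 nM.
Compound 2: `COc1cc(N(CC2CC2)c2ccccc2)cnc1C(=O)[C@H]1C[C@@H]1C(=O)O`, in this assay gives 1640 nM.
Compound 3: `COc1cc(N(CC(C)C)c2cccc(C(F)(F)F)c2)cnc1C(=O)[C@H]1C[C@@H]1C(=O)O`, in this assay gives 20.6 nM.

Among these three, compound 3 gives the lowest number in this assay, though compound 1 stands within the scatter of it, while compound 2 lies far away. The one single-point step shown is a 59-fold higher number from compound 1 to compound 2 (1.77 log units; beyond the scatter), a large change that concerns the aryl group on the nitrogen, not the chain.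

Compound 4, `COc1cc(N(Cc2ccc(F)cc2)c2cccc(C(F)(F)F)c2)cnc1C(=O)[C@H]1C[C@@H]1C(=O)O`, departs from compound 3 by 4-fluorophenyl in place of isopropyl on a saturated chain carbon bound to a nitrogen on an aromatic ring. Going by the values given here, no measured pair bears on this part of the molecule; compound 1 and compound 3 differ from each other at the chain as well as at the aryl group and their values in this assay fall within the scatter, which offers only weak guidance. With nothing pointing in either direction, the expected step of a 1.2-fold higher number from compound 3 to compound 4 (0.08 log units; within the scatter) is modest and of uncertain sign. Compound 4 is therefore estimated at 25 nM in this assay, within a range from 8 nM to 80 nM.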

Compound 4, half-maximal inhibitory concentration: 157 nM
Estimate against measurement, compound 4: 6.3-fold (0.80 log units) below; measured number above the stated range.
By their numbers in this assay, from the lowest: compounds 3 and 1 (each within the scatter of the next); then compound 4; then compound 2.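

The chain on the nitrogen proves not to be a silent position in this assay: with the aryl group kept, isobutyl to 4-fluorobenzyl brings a 7.6-fold higher number from compound 3 to compound 4 (0.88 log units; beyond the scatter). Until this step, the only single-point change shown concerned the aryl group, so this is the first direct reading of the chain. The larger group with its aromatic ring still leaves compound 4 at 157 nM, so the position accepts it, but at a cost beyond the scatter, and nothing available here bears on what lies behind that cost.

The compounds shown leave open whether the higher number goes with the ring or with its fluorine, and how a plain benzyl, a cyclohexylmethyl or a chain bearing an amine would read here. Going by these compounds, whether the same change would read alike with the 3,4-dichlorophenyl group of compound 1 on the nitrogen also stays open.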